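This account rests on a few compounds, and the source may have more. Where it says the series, first, only, none or still open, it means among the compounds named here.

The measured compounds are:

Compound 1, `N/C(=N\NC(=S)N1CCCCCC1)c1ccccn1`: 67%
Compound 2, `Cc1cccc(/C(N)=N/NC(=S)N2CCSCC2)n1`: 53.2%
Compound 3, `N/C(=N\NC(=S)N1CCSCC1)c1ccccn1`: 61.4%

All three were tested in a functional assay on A-431 cells (Homo sapiens) for cytotoxicity, read by MTT assay, with a stated time of 72 h, tested at 10 uM; a lower number here means less inhibition of growth, a higher number more inhibition of growth at the concentration tested. Compound 1 gives 67%, compound 3 gives 61.4%, and compound 2 gives 53.2%. The gap between compound 1 and compound 3 lies within the usual scatter of this kind of measurement, so nothing about their order can be read from it; the gap between compound 1 and compound 2 lies beyond it. The difference between the core of compound 1 and the core of compound 3 is not broken down here.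

Compounds 3 and 2 differ in one place only: methyl in place of hydrogen on an aromatic carbon. This change gives a number 8.2 percentage points lower from compound 3 to compound 2 (within the scatter) in this assay.

Compound 4, `Cc1cccc(/C(N)=N/NC(=S)N2CCCCCC2)n1`, has not yet been measured. It differs from compound 1 by the same change, (methyl in place of hydrogen on an aromatic carbon), made on the core of compound 1 rather than on the core of compound 3. Because the measured step of a number 8.2 percentage points lower from compound 3 to compound 2 (within the scatter) stayed within the scatter, the corresponding step from compound 1 to compound 4 is expected to be small as well, and the estimate is a number 7 percentage points lower from compound 1 to compound 4 (within the scatter). On that basis compound 4 is expected to give about 60% in this assay, with a likely range from 48% to 72%.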

Compound 4, percent growth inhibition at one concentration: 45.8%
Beside the measured number, compound 4's estimate is 14.2 percentage points above it, outside the stated range (below it).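

On the core of compound 1, methyl in place of hydrogen on the aromatic carbon next to the ring nitrogen gives a number 21.2 percentage points lower from compound 1 to compound 4 (beyond the scatter) in this assay. This step lies beyond the scatter, whereas the same change on the core of compound 3 stayed within it, but the two steps cannot be told apart, so the results are consistent with the change carrying over from one core to the other: the same change on two cores in this assay, a number 8.2 percentage points lower (within the scatter) from compound 3 to compound 2 and a number 21.2 percentage points lower (beyond the scatter) from compound 1 to compound 4, 13 percentage points apart, within the scatter of two such steps They do not show that the change acts differently on the two cores, nor do they fix one common size for the step, and two cores are too few to show how it would carry over to any other core in this series.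

The compounds shown leave open how an ethyl group, a methoxy group or an amine in place of the methyl would read in this assay, and whether methyl on another carbon of the aromatic ring would give a similar step. They also leave open whether the step seen here would hold at other concentrations or in other cells, since all of these numbers come from a single concentration in one cell line.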